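Acyl variation on the shared core: an aromatic ring enters

This account rests on a few compounds, and the source may have more. Where it says the series, first, only, none or still open, it means among the compounds named here.

Compound 1 `CCCC(=O)NC(=S)N1CCc2c(OCCCCCOc3ccc(Cl)cc3)cccc21` and compound 2 `O=C(NC(=S)N1CCc2c(OCCCCCOc3ccc(Cl)cc3)cccc21)C1CCCCC1` share one core and differ only in the group on a carbonyl carbon. In an ADME assay on Huh-7 cells (Homo sapiens) for cytotoxicity (a lower number here means that less compound is tolerated, a higher number that more compound is tolerated), compound 1 gives > 50000 nM, which is a limit of the assay. Compound 2 gives > 50000 nM, again a limit. The step that the two limits leave unreadable from compound 1 to compound 2 therefore cannot be sized; the limit of > 50000 nM in this assay, at which 2 of the 2 values shown sit, marks where both values sit. Compound 3 `O=C(NC(=S)N1CCc2c(OCCCCCOc3ccc(Cl)cc3)cccc21)c1ccno1` follows from compound 2 by 1,2-oxazol-5-yl in place of cyclohexyl on a carbonyl carbon. With no readable measured step, the expected step that the limit leaves unreadable from compound 2 to compound 3 is none beyond the scatter. Compound 3 is accordingly estimated in this assay at 70000 nM, within 35000 nM to 150000 nM.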

Compound 3, half-maximal cytotoxic concentration: 37100 nM
The estimate for compound 3 lay 1.9-fold (0.28 log units) above the measured number; measured number inside the range.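

Within the data shown here, compound 3 is the first compound here to give a number rather than a limit in this assay, so an aromatic ring with hetero atoms on the carbonyl carbon brings the value into the readable range. In place of cyclohexyl, 1,2-oxazol-5-yl gives an at least 1.3-fold lower number from compound 2 to compound 3 (0.12 log units; that floor lies within the scatter), and in place of propyl it gives an at least 1.3-fold lower number from compound 1 to compound 3 (0.12 log units; that floor lies within the scatter). The full size of both steps stays unknown, since compound 1 and compound 2 each stand at a limit: the limit of > 50000 nM in this assay, at which 2 of the 3 values shown sit.

The compounds shown leave open whether the aromatic ring or its hetero atoms go with the readable value. A phenyl group or a tetrahydrofuran-2-yl group on the same carbonyl carbon would separate the two.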